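Extending the ring nitrogen alkyl from isopropyl to isobutyl

The compounds below may be only part of what the source reports. "The series", "measured", "known", "first", "only" and "open" are said of these compounds alone.

The measured compounds:
Compound 1, `CN1C(=O)C=C(Cl)C1(O)c1ccccc1`, 2500 nM
Compound 2, `CC(C)N1C(=O)C=C(Cl)C1(O)c1ccccc1`, 200 nM
Compound 3, `CC(C)N1C(=O)C=C(Cl)C1(O)c1ccc(Cl)cc1`, 300 nM

All three numbers come from an assay on cell membranes for displacement of a labelled ligand from Cholecystokinin receptor type A (Rattus norvegicus), read by CCK-8 assay, with a stated time of 2 h; a higher number here means a weaker inhibitor, a lower number a stronger inhibitor. Compound 3 stands second highest of the three: it sits nearest compound 2, and the step from compound 2 to compound 3 is a 1.5-fold higher number from compound 2 to compound 3 (0.18 log units; within the scatter), so the two are not separated; compound 1 lies furthest away, with a clearly higher number than compound 3.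

Compound 4, `CC(C)CN1C(=O)C=C(Cl)C1(O)c1ccc(Cl)cc1`, has not yet been measured. It differs from compound 3 by isobutyl in place of isopropyl on an amide-type nitrogen in a ring. Going by the values given here, the only measured step at the same position is the one from compound 1 to compound 2, a 13-fold lower number from compound 1 to compound 2 (1.10 log units; beyond the scatter), which is large. The step from compound 2 to compound 3 concerns the aromatic chloro and does not bear on the nitrogen substituent. Whether a longer chain than isopropyl continues that gain is not shown by any measured pair, so the expectation rests on a single step and stays uncertain.

On that basis compound 4 is expected to give a somewhat lower number than compound 3, the estimated step being a 2.0-fold lower number from compound 3 to compound 4 (0.30 log units; within the scatter). Compound 4 is estimated at 150 nM in this assay, with a range from 40 nM to 600 nM.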

Compound 4, half-maximal inhibitory concentration: 8 nM
Compound 4: middle estimate off by 19-fold (1.27 log units), on the high side, and the stated range ends above it.
By their numbers in this assay, from the lowest: compound 4; then compounds 2 and 3 (each within the scatter of the next); then compound 1.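

In this assay, the gain on the ring nitrogen did not end at isopropyl: the change to isobutyl gave a 38-fold lower number from compound 3 to compound 4 (1.57 log units; beyond the scatter), a second large step at this position alongside a 13-fold lower number from compound 1 to compound 2 (1.10 log units; beyond the scatter). Going by these compounds alone, the number thus falls at each measured step along methyl, isopropyl and isobutyl, with no compound here going against that order, although the first step was read without the aromatic chloro and the second with it; the position therefore responds strongly even to a change as small as isopropyl to isobutyl. Nothing available explains why this one change on the amide-type nitrogen counts for so much.

What the compounds shown leave open is where this trend along the nitrogen substituent stops, since a longer chain such as n-pentyl, a more branched group such as neopentyl, or a ring-bearing group such as cyclopropylmethyl or benzyl could continue it or reverse it. It also remains open whether isobutyl brings a gain of similar size on the core without the aromatic chloro, as the shown isobutyl compound carries that chloro.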